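The source may report more compounds than this note shows. Statements on the series, on what has been measured and on what is new or still open speak of the compounds shown alone.

Compound 1 `Nc1ccccc1NC(=O)/C=C/c1ccc(CSc2ccc(Cl)cc2)cc1` — 55.3%
Compound 2 `Nc1ccccc1NC(=O)c1ccc(CSc2cccc(F)c2)cc1` — 46.9%
Compound 3 `Nc1ccccc1NC(=O)/C=C/c1ccc(CSc2cccc3ccccc23)cc1` — 59.3%

In a functional assay on A549 cells (Homo sapiens) for inhibition, read by CCK-8 assay, with a stated time of 72 h, tested at 2 uM (a lower number here means less inhibition of growth, a higher number more inhibition of growth at the concentration tested), compound 2 stands lowest of the three; compound 1 sits within the scatter of it, while compound 3 lies beyond. Compound 4 `Nc1ccccc1NC(=O)c1ccc(CSc2ccc(Cl)cc2)cc1` differs from compound 2 in one place: 4-chlorophenyl in place of 3-fluorophenyl on a sulfur. Going by the values given here, the only measured step on the group attached to the sulfur, a number 4 percentage points higher from compound 1 to compound 3 (within the scatter), concerns a different exchange in a different core and stays within the scatter; no measured pair shows this exact change. He therefore expects at most a small movement, if any, with the step from compound 2 to compound 4 estimated as a number 3.1 percentage points higher from compound 2 to compound 4 (within the scatter). His estimate for compound 4 in this assay is 50%, expected to fall between 38% and 62%.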

Compound 4, percent growth inhibition at one concentration: 47.3%
Beside the measured number, compound 4's estimate is 2.7 percentage points above it; measured number inside the range.
By their numbers in this assay, from the lowest: compounds 2, 4, 1 and 3 (each within the scatter of the next, the first and the last beyond it).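

In this assay the exchange of 3-fluorophenyl for 4-chlorophenyl on a sulfur gives a number 0.4 percentage points higher from compound 2 to compound 4 (within the scatter) in the shared core. Going by these compounds alone, this is the first measured pair for this exchange, and it shows that the two phenyl groups cannot be told apart in this read-out. Nothing available explains this result.

The compounds shown leave open whether an amine, a carboxylic acid or a longer chain on the sulfur would move the number. They also leave open whether this exchange would behave alike in the core of compound 1.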